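This account rests on a few compounds, and the source may have more. Where it says the series, first, only, none or still open, it means among the compounds named here.

Measured so far:
Compound 1, `COc1ccccc1/C=C/C[C@H]1C[C@@H]([C@@H](O)c2ccccc2)CO[C@@H]1c1ccccc1`: 14700 nM
Compound 2, `COc1cccc([C@H]2OC[C@H]([C@@H](O)c3ccc(OC)c(OC)c3)C[C@@H]2C/C=C/c2ccc(OC)c(OC)c2)c1`: 21800 nM
Compound 3, `COc1ccc([C@@H]2OC[C@H]([C@@H](O)c3ccc(OC)c(OC)c3)C[C@H]2C/C=C/c2ccc(OC)c(OC)c2)cc1`: 29200 nM

All three were tested in a functional assay on HeLa cells (Homo sapiens) for cytotoxicity, read by WST assay, with a stated time of 48 h; on this read-out higher numbers stand for weaker inhibition and lower numbers for stronger inhibition. Compound 1 gives the lowest of the three numbers, but the gap to compound 2 is within the scatter, as is the gap to compound 3, so the three cannot be placed in an order.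

Compound 4, `Oc1ccccc1/C=C/C[C@H]1C[C@@H]([C@@H](O)c2ccccc2)CO[C@@H]1c1ccccc1`, has not been measured. It differs from compound 1 in one place: hydrogen in place of methyl on an oxygen on an aromatic ring. For the measured compounds named here, no measured pair shows this same change, so its effect is unknown here. The change is small, and the expected step of a 1.0-fold higher number from compound 1 to compound 4 (0.01 log units; within the scatter) is therefore set at none beyond the scatter, in no particular direction. Compound 4 is thus expected to give about 15000 nM, with a range from 6000 nM to 40000 nM.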

Compound 4, half-maximal inhibitory concentration: 21800 nM
For compound 4 the middle estimate is 1.5-fold (0.16 log units) below the measured one; the range from low to high includes it.
By their numbers in this assay, from the lowest: compounds 1, 2, 4 and 3 (each within the scatter of the next).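

In this assay, going from methoxy to hydroxy gives a 1.5-fold higher number from compound 1 to compound 4 (0.17 log units; within the scatter). For the compounds shown here, this is the only direct one-place comparison so far, and it shows that at this position the methyl on the oxygen can be replaced by hydrogen with no difference that stands clear of the scatter. No supporting measurement bears on this result. The compounds shown leave open whether an amine, a fluorine or a longer chain on the oxygen at this place would read differently. They also leave open whether the same change would read alike on compound 2 or compound 3.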